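The source may hold more compounds than are shown below. What is called first, only, known or untested is meant among the compounds shown, and "the series" means these compounds.

Measured so far:
Compound 1, `COc1cc(Oc2cccc(Nc3ccccc3)c2)cc(OC)c1CNC(C)C`, in a functional assay on DLD-1 cells (Homo sapiens) for inhibition, read by MTT assay, with a stated time of 72 h (on this read-out lower numbers stand for stronger inhibition and higher numbers for weaker inhibition), reaches only > 20000 nM, which is a limit of the assay and not a number.
Compound 2, `COc1cc(Oc2cccc(Nc3ccccc3)c2)cc(OC)c1CCO`, in this assay gives 18100 nM.

Among the measured compounds shown here, compound 2 therefore holds the only real number among the two values shown; because compound 1 sits at the limit of > 20000 nM in this assay, at which 1 of the 2 values shown sits, no order between the two can be claimed. For the measured compounds named here, the one measured step, an at least 1.1-fold lower number from compound 1 to compound 2 (0.04 log units; that floor lies within the scatter), replaced a small amine by a hydroxymethyl on the saturated chain carbon bound to an aromatic carbon and moved the read-out by no more than a floor that lies within the scatter.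

Compound 3, `COc1cc(Oc2cccc(Nc3ccccc3)c2)cc(OC)c1CNCc1ccc(Br)cc1`, differs from compound 2 by (4-bromobenzyl)amino in place of hydroxymethyl on a saturated chain carbon bound to an aromatic carbon. Going by the values given here, the only step that bears on it is the same position's swap from compound 1 to compound 2, and that swap was small, so the evidence gives little direction. The entering group is much larger than the group that leaves, and the measured step offers no sign that the position is sensitive. The expected step, a 2.3-fold lower number from compound 2 to compound 3 (0.35 log units; beyond the scatter), is modest. Compound 3 is estimated in this assay at 8000 nM, within 2000 nM to 30000 nM.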

Compound 3, half-maximal inhibitory concentration: 3520 nM
Compound 3: middle estimate off by 2.3-fold (0.36 log units), on the high side; the measured number falls inside the stated range.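

In this assay, the saturated chain carbon bound to an aromatic carbon turns out to be a place where a change can register: the earlier swap there moved the read-out by no more than the scatter, whereas (4-bromobenzyl)amino in place of hydroxymethyl gives a 5.1-fold lower number from compound 2 to compound 3 (0.71 log units; beyond the scatter). An amine alone does not account for this, as compound 1 carries an amine too, and changing only the group on its nitrogen, with 4-bromobenzyl in place of isopropyl, gives an at least 5.6-fold lower number from compound 1 to compound 3 (0.75 log units; beyond the scatter). From the compounds shown here alone, compound 1 stands at a limit and not a number, so that second step is only a floor, and its true size stays unknown: the limit of > 20000 nM in this assay, at which 1 of the 3 values shown sits.

The compounds shown do not separate what the bromine contributes from what the aromatic ring contributes, as both enter together in a single change. A plain benzyl on the same nitrogen would speak to the bromine, while a cyclohexylmethyl or a phenylethyl group would speak to the ring and to the length of the chain that holds it.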